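The compounds below may be only part of what the source reports. "The series", "measured", "known", "first", "only" and "open" are said of these compounds alone.

Measured compounds in a toxicity assay on HepG2 cells (Homo sapiens) for inhibition, read by CellTiter-Glo, with a stated time of 48 h; a higher number here means a weaker inhibitor, a lower number a stronger inhibitor:
- compound 1, `Cc1cc(C)cc(NC(=O)COc2cc(C)nc3ccc(F)cc23)c1`: compound 1 gives 63100 nM.
- compound 2, `Cc1cc(C)cc(NC(=O)COc2cc(C)nc3ccc(C)cc23)c1`: compound 2 gives 15900 nM.
- compound 3, `COc1ccc2nc(C)cc(OCC(=O)Nc3c(C)cccc3C)c2c1`: for compound 3 this assay reports only a limit, > 100000 nM.

Compound 3 therefore stands at the edge of what this assay can report: it is one of the compounds at the limit of > 100000 nM in this assay, at which 1 of the 3 values shown sits, so no number for it is known, only that it is a weak inhibitor. Compound 4, `COc1ccc2nc(C)cc(OCC(=O)Nc3ccc(Cl)cc3Cl)c2c1`, is the unmeasured compound. It differs from compound 3 in one place: 2,4-dichlorophenyl in place of 2,6-dimethylphenyl on an amide-type nitrogen.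

Among the compounds with values here, only one measured step connects two compounds that differ in a single place, and that step is a 4.0-fold lower number from compound 1 to compound 2 (0.60 log units; beyond the scatter). It changes a group on the shared core, not the ring on the amide-type nitrogen, so it does not speak directly to the change from compound 3 to compound 4. Within the data shown here, with no step touching that ring, no direction can be read from the measured compounds. The step from compound 3 to compound 4 is therefore expected to be an at least 1.2-fold lower number from compound 3 to compound 4 (0.09 log units; that floor lies within the scatter), that is, none beyond the scatter, with a fair chance that compound 4 again ends at a limit. For compound 4 in this assay the estimate is 80000 nM, within a range from 20000 nM to 250000 nM.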

Compound 4, half-maximal inhibitory concentration: > 100000 nM
Compound 4 was reported as a limit; the forecaster's own chance of this, stated with the estimate: 50%; middle value at least 1.2-fold (0.09 log units) away from the limit.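

In this assay, within the data shown here, compound 4 gives only a limit, just as compound 3 does, so no step between compound 3 and compound 4 can be read: the limit of > 100000 nM in this assay, at which 2 of the 4 values shown sit. The compounds shown leave open whether 2,4-dichlorophenyl in place of 2,6-dimethylphenyl on the amide-type nitrogen changes the result in this assay at all.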